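Removing one chloro from the fused ring of compound 1

This account rests on a few compounds, and the source may have more. Where it says the series, first, only, none or still open, it means among the compounds named here.

Measured compounds:
compound 1 `CCC1(CCCCN2CCN(c3cccc(Cl)c3)CC2)C(=O)Nc2c(Cl)cc(Cl)cc21` gives 9.46 nM in an assay on CHO cells for displacement of a labelled ligand from 5-hydroxytryptamine receptor 7 (Homo sapiens); a higher number here means a weaker inhibitor, a lower number a stronger inhibitor
compound 2 `CCC1(CCCCN2CCN(c3ccc(F)cc3)CC2)C(=O)Nc2ccccc21` gives 0.43 nM
compound 3 `CCC1(CCCCN2CCN(c3ccc(F)c(Cl)c3)CC2)C(=O)Nc2ccccc21` gives 0.6 nM

Compound 4 `CCC1(CCCCN2CCN(c3cccc(Cl)c3)CC2)C(=O)Nc2ccc(Cl)cc21` is compound 1 with one change: hydrogen in place of chloro on an aromatic carbon. The same kind of change has been measured once, from compound 3 to compound 2: hydrogen in place of chloro on an aromatic carbon, where the step was a 1.4-fold lower number from compound 3 to compound 2 (0.14 log units; within the scatter). The surroundings are not the same: in compound 4 the place is part of a fused or bridged system of two rings, ortho to a fused ring and meta to a chloro group, whereas in compound 2 it is ortho to a fluoro group and meta to a large group. The difference between the core of compound 1 and that of compound 3 is not broken down here.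

Compound 1 stands highest in this assay, well beyond the scatter from compound 3. Because compound 1 gives 9.46 nM while compound 3 gives 0.6 nM, some of that gap may come from the chloro that leaves, so compound 4 is expected to take a step of a 2.4-fold lower number from compound 1 to compound 4 (0.37 log units; beyond the scatter). Compound 4 is estimated at 4 nM, likely between 1.5 nM and 12 nM.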

Compound 4, inhibition constant: 8.27 nM
Compound 4: the middle estimate sits 2.1-fold (0.32 log units) below what was measured, and the stated range covers the measured number.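

In this assay, putting hydrogen in place of this chloro gives a 1.1-fold lower number from compound 1 to compound 4 (0.06 log units; within the scatter). Set beside the earlier case, the same change gives a similar result on the two cores: the same change on two cores in this assay, a 1.4-fold lower number (0.14 log units; within the scatter) from compound 3 to compound 2 and a 1.1-fold lower number (0.06 log units; within the scatter) from compound 1 to compound 4, 1.2-fold (0.09 log units) apart, within the scatter of two such steps. Going by these compounds alone, this rests on only two pairs, with the chloro in different surroundings in each, so it shows that neither step moved the number beyond the scatter, not that the change would do the same on every core or at every place on a ring.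

The compounds shown leave open what removing the remaining chloro from compound 4 would do. They also leave open whether a methoxy group, a nitrile or an amine at the same place would fare like hydrogen.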